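The source may report more compounds than this note shows. Statements on the series, on what has been measured and on what is new or still open speak of the compounds shown alone.

Measured so far in a functional assay on HCT-116 cells (Homo sapiens) for cytotoxicity, read by sulforhodamine B assay, with a stated time of 48 h; a higher number here means a weaker inhibitor, a lower number a stronger inhibitor:
- compound 1 `CCC(=O)n1nc(NC(=O)c2ccccc2)c2c1CN(C(=O)c1ccccc1)C2` gives 1060 nM
- compound 2 `CC(C)C(=O)n1nc(NC(=O)c2ccccc2)c2c1CN(C(=O)c1ccccc1)C2` gives 2020 nM
- compound 3 `CC(=O)n1nc(NC(=O)c2ccccc2)c2c1CN(C(=O)c1cccc([N+](=O)[O-])c1)C2` gives 17300 nM

Compound 3 has the highest number of the three, which makes it the weakest. Compound 4 `CC(=O)n1nc(NC(=O)c2ccccc2)c2c1CN(C(=O)c1ccncc1)C2` carries pyridin-4-yl in place of 3-nitrophenyl on a carbonyl carbon. Within the data shown here, no measured step tests this swap. Among the measured compounds shown here, the only step available, a 1.9-fold higher number from compound 1 to compound 2 (0.28 log units; within the scatter), lies within the scatter and concerns a different place in the molecule. Compound 1 (1060 nM) and compound 2 (2020 nM) lack the 3-nitrophenyl group and have lower numbers, but they also differ from compound 3 in a second place, so they offer only a weak hint. A modest downward move is therefore expected (a 2.2-fold lower number from compound 3 to compound 4 (0.33 log units; beyond the scatter)). The estimate for compound 4 is 8000 nM (expected range 2000 nM to 30000 nM).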

Compound 4, half-maximal inhibitory concentration: 10000 nM
Beside the measured number, compound 4's estimate is 1.3-fold (0.10 log units) below it; the range from low to high includes it.
By their numbers in this assay, from the lowest: compounds 1 and 2 (each within the scatter of the next); then compounds 4 and 3 (each within the scatter of the next).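

In this assay, placing pyridin-4-yl instead of 3-nitrophenyl on the carbonyl carbon gives a 1.7-fold lower number from compound 3 to compound 4 (0.24 log units; within the scatter). This first direct test of the position therefore shows that exchanging these two aromatic groups, with fewer heavy atoms in the one that enters, produces no change that can be told from scatter. No measurement at hand explains this result.

Still open, from the compounds shown here alone, is whether an amine or a longer carbon chain on this carbonyl carbon would shift the number beyond the scatter.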